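A few compounds are considered here, and "the series" means these few. Any claim that something is new, unique, unknown or untested is made for them only; others in the source may bear on it.

Two compounds of this series have values. Compound 1 `CCc1ccc(-c2nc(N)c3cc(Cc4ccccc4)sc3n2)o1` gives 223 nM in a functional assay on CHO-K1 cells for antagonist activity at adenosine receptor A1 (Homo sapiens), read by a beta-galactosidase reporter and cAMP accumulation, with stated times of 15 min and 6 h; a higher number here means a weaker inhibitor, a lower number a stronger inhibitor; compound 2 `Nc1nc(-c2ncccn2)nc2sc(Cc3ccccc3)cc12` gives 618 nM and so stands with the higher of the two numbers. Going by the values given here, the one step so far, a 2.8-fold higher number from compound 1 to compound 2 (0.44 log units; beyond the scatter), varies the same position that is now changed again. Compound 3 `Nc1nc(-c2cccc(Cl)n2)nc2sc(Cc3ccccc3)cc12` carries 6-chloropyridin-2-yl in place of pyrimidin-2-yl on an aromatic carbon. Among the compounds with values here, that single step shows the position tolerates an aryl exchange with modest effect; no measured pair tests a chloropyridyl group. The expected step from compound 2 to compound 3 is therefore small, a 1.4-fold lower number from compound 2 to compound 3 (0.14 log units; within the scatter), in either direction. Compound 3 is estimated at 450 nM, within 150 nM to 1400 nM.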

Compound 3, inhibition constant: > 1000 nM
Compound 3: a limit, no number; the forecaster's own chance of this, stated with the estimate: 3%; at least 2.2-fold (0.34 log units) between middle value and limit.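

Compound 3 gives a limit of the assay, not a number: the limit of > 1000 nM in this assay, at which 1 of the 3 values shown sits. The exchange of pyrimidin-2-yl for 6-chloropyridin-2-yl is an at least 1.6-fold higher number from compound 2 to compound 3 (0.20 log units; that floor lies within the scatter), so its floor alone does not separate this change from the scatter. The exchange of 5-ethylfuran-2-yl for 6-chloropyridin-2-yl is an at least 4.4-fold higher number from compound 1 to compound 3 (0.65 log units; beyond the scatter), which leaves compound 1 with the lowest number of the three and shows that this position does not treat all aromatic groups alike.

The 6-chloropyridin-2-yl group differs from pyrimidin-2-yl in both chlorine and ring nitrogen, and the compounds shown do not separate the two. From the compounds shown here alone, how an unsubstituted pyridin-2-yl or a furan-2-yl without the ethyl chain would read here remains open.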